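A few compounds are considered here, and "the series" means these few. Any claim that something is new, unique, unknown or untested is made for them only; others in the source may bear on it.

Working notes on a small set of purine derivatives tested in an ADME assay on MCF7 cells (Homo sapiens) for cytotoxicity, with a stated time of 72 h; a higher number here means a weaker inhibitor, a lower number a stronger inhibitor.

Compound 1, `Oc1ccccc1CNc1ncnc2c1ncn2C1CCCCO1`, sits at the limit of this assay: in this assay compound 1 gives > 100000 nM, which is a limit of the assay and not a number. Compound 2, `COc1cccc(CNc2ncnc3c2ncn3C2CCCCO2)c1O`, differs from compound 1 by methoxy in place of hydrogen on an aromatic carbon. In this assay compound 2 also gives > 100000 nM, again a limit rather than a number. The step that the two limits leave unreadable from compound 1 to compound 2 is therefore not readable from these two values. Compound 3, `COc1ccc(CNc2ncnc3c2ncn3C2CCCO2)cc1`, has the same atoms as compound 1 joined differently; the difference between the two cores is not broken down here. In this assay compound 3 gives > 100000 nM, which is a limit of the assay. All three measured values sit at the limit of > 100000 nM in this assay, at which 3 of the 3 values shown sit.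

Compound 4, `COc1ccc(CNc2ncnc3c2ncn3C2CCCO2)cc1OC`, is not yet measured. It differs from compound 3 by methoxy in place of hydrogen on an aromatic carbon. This is the same kind of change as that from compound 1 to compound 2, but the surroundings differ: in compound 2 the entering methoxy sits ortho to a hydroxy group (1 heavy atom), whereas in compound 4 it sits ortho to a methoxy group (2 heavy atoms). Since compound 1, compound 2 and compound 3 all sit at the limit of > 100000 nM in this assay, at which 3 of the 3 values shown sit, and the step from compound 1 to compound 2 did not bring a readable value, the expectation for compound 4 is that the step that the limit leaves unreadable from compound 3 to compound 4 stays unreadable as well. Compound 4 is accordingly estimated at 150000 nM, with the likely outcome being another limit rather than a number.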

Compound 4, half-maximal inhibitory concentration: > 100000 nM
Compound 4: no number, only a limit (the forecaster's own chance of this, stated with the estimate: 85%); the middle value does not contradict the limit.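

In this assay compound 4 gives > 100000 nM, which is a limit of the assay and not a number. Among these compounds, compound 3 also stands at a limit, so no step from one to the other can be read. The compounds shown leave open whether methoxy in place of hydrogen on an aromatic carbon changes the read-out at all, as every value stands at one point: the limit of > 100000 nM in this assay, at which 4 of the 4 values shown sit.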